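The compounds below may be only part of what the source reports. "The series", "measured", "known", "first", "only" and "open" are said of these compounds alone.

Compound 1 `CC(C)c1onc(-c2c(Cl)cccc2Cl)c1COc1ccc(-c2nc3ccc(C(=O)O)cc3n2-c2ccc(F)cc2)cc1`, measured in an assay on HEK-293T cells for antagonist activity at vitamin D3 receptor (Homo sapiens), read by a luciferase reporter, with a stated time of 24 h (a higher number here means a weaker inhibitor, a lower number a stronger inhibitor), gives 2410 nM. Compound 2 `CC(C)Cn1c(-c2ccc(OCc3c(-c4c(Cl)cccc4Cl)noc3C(C)C)cc2)nc2ccc(C(=O)O)cc21` gives 1180 nM.

Compound 2 holds the lower of the two numbers. For the measured compounds named here, its only neighbour is compound 1, and the single change between them, isobutyl in place of 4-fluorophenyl on an aromatic nitrogen, brought a 2.0-fold lower number from compound 1 to compound 2 (0.31 log units; beyond the scatter), a modest step but one beyond the scatter.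

Compound 3 `CC(C)c1onc(-c2c(Cl)cccc2Cl)c1COc1ccc(-c2nc3ccc(C(=O)O)cc3n2CC2CCCCC2)cc1` is not yet measured. It differs from compound 2 by cyclohexyl in place of isopropyl on a saturated chain carbon bound to an aromatic nitrogen. Going by the values given here, the one measured step bears on the same position, the substituent on the aromatic nitrogen, and it shows that variation there moves the number only modestly. Because a 2.0-fold lower number from compound 1 to compound 2 (0.31 log units; beyond the scatter) was modest, and because the present change keeps a saturated chain on that nitrogen, compound 3 is expected to stay near compound 2, with a 1.4-fold lower number from compound 2 to compound 3 (0.14 log units; within the scatter) as the estimated step, if anything a slightly lower number but possibly within the scatter. In this assay compound 3 is therefore estimated at 850 nM, within a range of 300 nM to 2500 nM.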

Compound 3, half-maximal inhibitory concentration: 346 nM
Compound 3: middle estimate off by 2.5-fold (0.39 log units), on the high side; measured number inside the range.
By their numbers in this assay, from the lowest: compound 3; then compound 2; then compound 1.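

In this assay, the substituent on the aromatic nitrogen proves able to move the number further than the first step suggested: cyclohexyl in place of isopropyl on a saturated chain carbon bound to that nitrogen brings a clear gain (a 3.4-fold lower number from compound 2 to compound 3 (0.53 log units; beyond the scatter)). Measured against the 4-fluorophenyl group, cyclohexylmethyl gives the widest step among these compounds (a 7.0-fold lower number from compound 1 to compound 3 (0.84 log units; beyond the scatter)), and compound 3 holds the lowest number of the three, with its steps to both others beyond the scatter. No measurement given here offers a reason for this gain.

The compounds shown leave open whether the gain needs a ring at all, or whether an open hexyl chain on the same carbon would serve as well. They also leave open how a piperidine ring, which carries an amine, would fare in place of cyclohexyl.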